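A few compounds are considered here, and "the series" means these few. Any claim that something is new, unique, unknown or untested is made for them only; others in the source may bear on it.

Measured compounds:
- compound 1, `Cc1nc(N)sc1CCCN/C(N)=N/C(=O)N[C@H](C)c1ccccc1`: 45.7 nM
- compound 2, `CCCNC(=O)/N=C(\N)NCCCc1sc(N)nc1C`: 170 nM
- compound 3, `Cc1nc(N)sc1CCCN/C(N)=N/C(=O)Nc1ccccc1`: 3390 nM

All three were tested in a functional assay on HEK293T cells for agonist activity at histamine H2 receptor (Homo sapiens), read by beta-arrestin recruitment; a lower number here means that less compound is needed, a higher number that more compound is needed for the effect. Compound 2 stands second highest of the three numbers: its nearest neighbour is compound 1, which lies lower by a 3.7-fold higher number from compound 1 to compound 2 (0.57 log units; beyond the scatter), and its furthest is compound 3, which lies higher by a 20-fold higher number from compound 2 to compound 3 (1.30 log units; beyond the scatter).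

The unmeasured compound 4, `Cc1nc(N)sc1CCCN/C(N)=N/C(=O)NCC(C)CCCc1ccccc1`, arises from compound 2 by one change: 3-phenylpropyl in place of hydrogen on a saturated chain carbon bound to two saturated chain carbons. The chain on the amide-type nitrogen thus stays saturated but becomes branched and carries a distant benzene ring.

Within the data shown here, two measured steps bear on this. Going from compound 1 to compound 2, a branched group carrying a phenyl was replaced by plain propyl, and the number rose by a 3.7-fold higher number from compound 1 to compound 2 (0.57 log units; beyond the scatter). Going from compound 2 to compound 3, the chain was replaced by phenyl bound directly to the nitrogen, and the number rose by a 20-fold higher number from compound 2 to compound 3 (1.30 log units; beyond the scatter). Compound 4 keeps a saturated link to the nitrogen, like compound 1, so a modest drop is expected, about a 2.1-fold lower number from compound 2 to compound 4 (0.33 log units; beyond the scatter). The estimate for compound 4 in this assay is 80 nM, within 25 nM to 300 nM.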

Compound 4, half-maximal effective concentration: 2510 nM
Estimate against measurement, compound 4: 31-fold (1.50 log units) below, and the stated range ends below it.
By their numbers in this assay, from the lowest: compound 1; then compound 2; then compounds 4 and 3 (each within the scatter of the next).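

In this assay, placing 3-phenylpropyl on a saturated chain carbon bound to two saturated chain carbons raises the number sharply (a 15-fold higher number from compound 2 to compound 4 (1.17 log units; beyond the scatter)), so this position does not accept this group without a large change. The earlier step, in which a benzene-bearing group gave way to plain propyl (a 3.7-fold higher number from compound 1 to compound 2 (0.57 log units; beyond the scatter)), pointed the other way, and compound 4 shows that a benzene ring on a saturated chain does not by itself bring a lower number. No measurement shown here explains this reversal.

As far as these compounds go, it remains open whether the rise comes with the branch itself or with the distant benzene ring. A lone methyl at this carbon, or 3-cyclohexylpropyl in place of 3-phenylpropyl, would separate these two parts of the change.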